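The compounds below may be only part of what the source reports. "The series", "measured", "known", "first", "only" and "open" are said of these compounds alone.

Among the measured compounds shown here, compound 1 `CC(C)CNc1ccc(NC(=O)c2cc(Cl)ccc2O)c(Cl)c1` stands second highest of the three numbers so far in an ADME assay on A549 cells (Homo sapiens) for cytotoxicity, read by resazurin assay, with a stated time of 48 h (a higher number here means that more compound is tolerated, a lower number that less compound is tolerated), where compound 1 gives 60000 nM. Compound 2 `CCCCCCC(C)Nc1ccc(NC(=O)c2cc(Cl)ccc2O)c(Cl)c1` gives 23500 nM in this assay, and compound 3 `CC1(Nc2ccc(NC(=O)c3cc(Cl)ccc3O)c(Cl)c2)CCCC1` gives 157000 nM. Compound 4 `O=C(Nc1ccc(NCc2cccc(C(F)(F)F)c2)cc1Cl)c1cc(Cl)ccc1O` is still to be measured. It differs from compound 1 in one place: 3-(trifluoromethyl)phenyl in place of isopropyl on a saturated chain carbon bound to a nitrogen on an aromatic ring. For the measured compounds named here, no measured step exchanges isobutyl for an aromatic group at this carbon; the steps that bear on it all alter the group on the same nitrogen on an aromatic ring. The step of a 2.6-fold lower number from compound 1 to compound 2 (0.41 log units; beyond the scatter) lowered the number, the step of a 2.6-fold higher number from compound 1 to compound 3 (0.42 log units; beyond the scatter) raised it, and the step of a 6.7-fold higher number from compound 2 to compound 3 (0.82 log units; beyond the scatter) is the largest of the three. All three are modest, so a change at this position is expected to move the number by a modest amount; the longer open chain of compound 2 went down, the ring of compound 3 went up. With an aromatic ring entering on a saturated chain carbon, the expected step of a 2.0-fold lower number from compound 1 to compound 4 (0.30 log units; within the scatter) is a modest decrease, with wide uncertainty. Compound 4 is therefore estimated at 30000 nM, within 10000 nM to 90000 nM.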

Compound 4, half-maximal cytotoxic concentration: 13300 nM
The estimate for compound 4 lay 2.3-fold (0.35 log units) above the measured number; measured number inside the range.
By their numbers in this assay, from the lowest: compounds 4 and 2 (each within the scatter of the next); then compound 1; then compound 3.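

In this assay, putting 3-(trifluoromethyl)phenyl on the saturated chain carbon gives a 4.5-fold lower number from compound 1 to compound 4 (0.65 log units; beyond the scatter), so an aromatic ring at this place lowers the number. Compound 3 had suggested that a ring on this nitrogen might raise it, with a 2.6-fold higher number from compound 1 to compound 3 (0.42 log units; beyond the scatter), but compound 4 shows that the presence of a ring alone does not set the direction, and its number lies within the scatter of that of compound 2, the long open-chain compound. Nothing measured here explains this drop.

The compounds shown leave open whether the change comes from the phenyl ring itself or from its trifluoromethyl group, as they include no plain benzyl group. They also leave open how a ring carrying a nitrile or a carboxylic acid would behave at this place.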